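From 2-methoxyethyl to 2-acetoxyethyl on the shared core

This account rests on a few compounds, and the source may have more. Where it says the series, first, only, none or still open, it means among the compounds named here.

In a functional assay (trachea) with Cavia porcellus as the target (on this read-out higher numbers stand for weaker inhibition and lower numbers for stronger inhibition), compound 1 `Cn1nc(-c2cccnc2)c2ccccc2c1=O` gives 11500 nM, and compound 2 `COCCn1nc(-c2cccnc2)c2ccccc2c1=O` gives 9330 nM. Going by the values given here, these are the only two numbers so far, and they lie within the scatter of each other, so compound 2 stands level with compound 1.

Compound 3 `CC(=O)OCCn1nc(-c2cccnc2)c2ccccc2c1=O` keeps the shared core and differs from compound 2 by acetyl in place of methyl on an oxygen on a saturated carbon. This is acetyl in place of methyl on an oxygen on a saturated carbon, or 2-acetoxyethyl in place of 2-methoxyethyl.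

Among the compounds with values here, only one measured step bears on this change: a 1.2-fold lower number from compound 1 to compound 2 (0.09 log units; within the scatter). That step built the chain on the aromatic nitrogen and stayed within the scatter. Within the data shown here, no measured compound carries an acetyl group, so the evidence for this change is thin. No shift beyond the scatter is expected in this assay, and no direction is favoured.

The estimated step is a 1.0-fold lower number from compound 2 to compound 3 (0.02 log units; within the scatter). For compound 3 the expected value is 9000 nM, with an estimated range of 3500 nM to 25000 nM.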

Compound 3, half-maximal inhibitory concentration: 9770 nM
Estimate against measurement, compound 3: 1.1-fold (0.04 log units) below, and the stated range covers the measured number.
By their numbers in this assay, from the lowest: compounds 2, 3 and 1 (each within the scatter of the next).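

Working from compound 2, acetyl in place of methyl on an oxygen on a saturated carbon gives a 1.0-fold higher number from compound 2 to compound 3 (0.02 log units; within the scatter) in this assay, so this exchange, which brings in a carbonyl and one hydrogen-bond acceptor, does not move the read-out beyond the scatter. Measured against the methyl group of compound 1, the full 2-acetoxyethyl chain gives a 1.2-fold lower number from compound 1 to compound 3 (0.07 log units; within the scatter), so compounds 1, 2 and 3 now stand level, and an ether and an ester on this chain cannot be told apart in this read-out. No available evidence offers a reason for this level outcome.

The compounds shown leave open whether any group on the aromatic nitrogen can move the read-out beyond the scatter, since the methyl, 2-methoxyethyl and 2-acetoxyethyl groups are the only ones in hand. A 2-hydroxyethyl, 2-aminoethyl or carboxymethyl group, or a longer chain such as 4-methoxybutyl, would test this position more widely, and the present numbers give no direction for any of them.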